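Notes on amide substituents on the shared core

The compounds below may be only part of what the source reports. "The series", "measured", "known", "first", "only" and "open" are said of these compounds alone.

Measured in an assay on cell membranes for binding affinity to 2-oxoglutarate receptor 1 (Rattus norvegicus), read by radioligand binding; on this read-out lower numbers stand for stronger inhibition and higher numbers for weaker inhibition:
compound 1 `CCC(C)NC(=O)[C@H]1OC(n2cnc3c(N)ncnc32)[C@H](O)[C@@H]1O`: 198 nM
compound 2 `Nc1ncnc2c1ncn2[C@@H]1O[C@H](C(=O)NC2CCCC2)[C@@H](O)[C@H]1O`: 49 nM
compound 3 `C[C@H]1CC[C@H](NC(=O)[C@H]2O[C@@H](n3cnc4c(N)ncnc43)[C@H](O)[C@@H]2O)CC1`: 12.9 nM

Compound 1 gives the highest number of the three in this assay; compound 2 and compound 3 both lie below it, each beyond the scatter. Going by the values given here, the single step read so far, a 3.8-fold lower number from compound 2 to compound 3 (0.58 log units; beyond the scatter), exchanges one ring for another on the amide-type nitrogen and does not touch the kind of change made here. Compound 4 `CC(C)CONC(=O)[C@H]1OC(n2cnc3c(N)ncnc32)[C@H](O)[C@@H]1O` differs from compound 1 by isobutoxy in place of sec-butyl on an amide-type nitrogen. Among the compounds with values here, no measured pair replaces an alkyl group with an alkoxy group on that nitrogen, so nothing in the set anchors the direction. For compound 4 the expected step is a 2.0-fold higher number from compound 1 to compound 4 (0.31 log units; beyond the scatter), with a wide range attached. The estimate for compound 4 in this assay is 400 nM, between 100 nM and 2000 nM.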

Compound 4, inhibition constant: 20 nM
The estimate for compound 4 lay 20-fold (1.30 log units) above the measured number, and the stated range ends above it.
By their numbers in this assay, from the lowest: compounds 3 and 4 (each within the scatter of the next); then compound 2; then compound 1.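

In this assay, isobutoxy in place of sec-butyl on an amide-type nitrogen gives a 9.9-fold lower number from compound 1 to compound 4 (1.00 log units; beyond the scatter), so an entering group with an oxygen can lower the number at this position. Going by these compounds alone, the only earlier step exchanged one ring for another, so this is the first read on a change between open-chain groups there. Nothing measured here accounts for the step.

The compounds shown leave open whether the oxygen or the change in chain carries the step; isobutyl on the same nitrogen would separate the two. Going by these compounds, how methoxy or a longer alkoxy chain behaves there also remains open.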